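Methoxy in place of methyl on an aromatic carbon

The source may hold more compounds than are shown below. What is called first, only, known or untested is meant among the compounds shown, and "the series" means these compounds.

Compound 1 `Cc1nc2cc(-c3cccc(-c4ccccc4)c3)nn2c(-c2cc(F)c3c(c2C)CCCO3)c1[C@H](OC(C)(C)C)C(=O)O`: 96%
Compound 2 `Cc1ccccc1-c1cccc(-c2cc3nc(C)c([C@H](OC(C)(C)C)C(=O)O)c(-c4cc(F)c5c(c4C)CCCO5)n3n2)c1`: 97%

In an ADME assay on microsomes from liver (Rattus norvegicus), read by LC-MS, using NADPH, with a stated time of 10 min, tested at 0.5 uM (a lower number here means that less of the compound is left, a higher number that more of the compound is left), compound 2 gives 97%, level with compound 1 at 96% within the scatter, so nearly all of both compounds is left. Compound 3 `COc1ccccc1-c1cccc(-c2cc3nc(C)c([C@H](OC(C)(C)C)C(=O)O)c(-c4cc(F)c5c(c4C)CCCO5)n3n2)c1` differs from compound 2 by one change, methoxy in place of methyl on an aromatic carbon, 2-methylphenyl to 2-methoxyphenyl. Among the compounds with values here, one measured step bears on it, the replacement of hydrogen by methyl on an aromatic carbon, a number 1 percentage points higher from compound 1 to compound 2 (within the scatter). Within the data shown here, that step stays within the scatter, but no measured compound carries a methoxy group, so the evidence is indirect. The expected step, a number 5 percentage points lower from compound 2 to compound 3 (within the scatter), is therefore a small one that does not go beyond the scatter. For compound 3 the estimated value is 92%, with an expected range from 80% to 98%.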

Compound 3, percent of the compound remaining: 99%
Compound 3: middle estimate off by 7 percentage points, on the low side; the whole stated range lies below it.
By their numbers in this assay, from the lowest: compounds 1, 2 and 3 (each within the scatter of the next).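

In this assay the change from methyl to methoxy gives a number 2 percentage points higher from compound 2 to compound 3 (within the scatter) and the change from hydrogen to methoxy gives a number 3 percentage points higher from compound 1 to compound 3 (within the scatter) at this same aromatic carbon. The earlier pair had shown only hydrogen and methyl here, whereas compound 3 shows that methoxy, with its oxygen and hydrogen-bond acceptor, also leaves nearly all of the compound in place, level with the other two. No measurement given here explains why this reading holds across the three groups.

All three readings lie so close together, near the top of the scale, that this assay does not separate these groups. Going by these compounds, whether an amine, a carboxylic acid or a longer chain such as ethoxy on this carbon would leave as much of the compound remaining stays open.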